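Fluoro on the phenyl of the tetrazole hydrazone

A few compounds are considered here, and "the series" means these few. Any claim that something is new, unique, unknown or untested is made for them only; others in the source may bear on it.

Three compounds of the series have been run in an ADME assay on NIH3T3 cells (Mus musculus) for cytotoxicity, read by MTT assay, with a stated time of 24 h; on this read-out higher numbers stand for weaker inhibition and lower numbers for stronger inhibition. Compound 1 `Cn1nnnc1SCC(=O)N/N=c1/scc(-c2ccccc2)n1-c1ccccc1` gives 173 ug/mL; compound 2 `Cn1cnnc1SCC(=O)N/N=c1/scc(-c2ccccc2)n1-c1ccccc1` gives 217 ug/mL; compound 3 `Cc1nnc(SCC(=O)N/N=c2/scc(-c3ccccc3)n2-c2ccccc2)s1` gives 197 ug/mL. Compound 1 holds the lowest of the three numbers, but neither a 1.3-fold higher number from compound 1 to compound 2 (0.10 log units; within the scatter) nor a 1.1-fold higher number from compound 1 to compound 3 (0.06 log units; within the scatter) reaches beyond the scatter, and a 1.1-fold lower number from compound 2 to compound 3 (0.04 log units; within the scatter) is likewise within it. Across the three, changing the ring on the sulfur has left the read-out essentially unmoved.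

Compound 4 `Cn1nnnc1SCC(=O)N/N=c1/scc(-c2ccc(F)cc2)n1-c1ccccc1` has not yet been run. It differs from compound 1 by fluoro in place of hydrogen on an aromatic carbon, on the far side of the core from the sulfur-linked ring that was varied among compounds 1, 2 and 3. Going by the values given here, no measured step touches this position, so the change stands without direct precedent. Among the compounds with values here, the only guidance is that the core has so far tolerated a variation elsewhere without any step beyond the scatter, and a single added fluorine is a small change.

Compound 4 is therefore expected to give 170 ug/mL in this assay, between 95 ug/mL and 300 ug/mL, meaning an expected step of a 1.0-fold lower number from compound 1 to compound 4 (0.01 log units; within the scatter) that is not expected to exceed the scatter.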

Compound 4, half-maximal inhibitory concentration: 113 ug/mL
For compound 4 the middle estimate is 1.5-fold (0.18 log units) above the measured one; the range from low to high includes it.
By their numbers in this assay, from the lowest: compounds 4, 1, 3 and 2 (each within the scatter of the next).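

In this assay, going from phenyl to 4-fluorophenyl gives a 1.5-fold lower number from compound 1 to compound 4 (0.18 log units; within the scatter) and so stays inside the scatter, as did the changes to the sulfur-linked ring among compounds 1, 2 and 3. Going by these compounds alone, this adds a second site to the picture: the aromatic carbon para to a large group accepts fluoro in place of hydrogen with no step that can be separated from repeat measurements, so the tolerance seen at the sulfur-linked ring is now matched by this one substitution on the far side of the shared core. No supporting measurement is available to account for the size or direction of this step.

The single fluoro leaves open whether this position stays as tolerant of larger or charged groups, such as trifluoromethyl, methoxy, an amine or a carboxylic acid, and a step beyond the scatter may yet appear with one of these. As far as these compounds go, it also remains open whether 4-fluorophenyl behaves the same way when paired with the rings of compound 2 and compound 3, and whether the second phenyl of the core tolerates the same change.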